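Removing the chloro from compound 2

A few compounds are considered here, and "the series" means these few. Any claim that something is new, unique, unknown or untested is made for them only; others in the source may bear on it.

- compound 1 `O=C1NC(c2ccc(Br)cc2)CN1S(=O)(=O)c1ccc2c(c1)CCC2` gives 32600 nM
- compound 2 `O=C1NC(c2ccc(Cl)cc2)CN1S(=O)(=O)c1ccc2c(c1)CCC2` gives 64300 nM
- compound 3 `O=C1NC(c2ccccc2)CN1S(=O)(=O)c1ccccc1` gives 116000 nM
- compound 4 `O=C1NC(c2ccccc2)CN1S(=O)(=O)c1ccc2c(c1)CCC2` awaits measurement

All of these numbers come from a functional assay on SK-MEL-2 cells (Homo sapiens) for cytotoxicity; on this read-out lower numbers stand for stronger inhibition and higher numbers for weaker inhibition. Compound 2 sits in the middle of the three values, and its gaps to compound 1 and compound 3 both lie within the scatter. The next step is to compound 4, which has hydrogen in place of chloro on an aromatic carbon. Going by the values given here, the one measured step at this same kind of site is a 2.0-fold higher number from compound 1 to compound 2 (0.29 log units; within the scatter), with chloro in place of bromo. That step is small, so it gives little reason to expect a large change here. Compound 3 also carries neither chloro nor bromo and gives 116000 nM, but it differs from compound 4 elsewhere too, so it is only a loose guide. A modest shift toward a higher number is expected, with no clear move beyond the scatter. The estimated change is a 1.4-fold higher number from compound 2 to compound 4 (0.15 log units; within the scatter). For compound 4 the expected value is 90000 nM, with an estimated range of 45000 nM to 180000 nM.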

Compound 4, half-maximal inhibitory concentration: 2 nM
Beside the measured number, compound 4's estimate is 45000-fold (4.65 log units) above it, outside the stated range (below it).
By their numbers in this assay, from the lowest: compound 4; then compounds 1, 2 and 3 (each within the scatter of the next, the first and the last beyond it).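

In this assay, going by these compounds alone, the group at this spot on the aromatic ring counts for far more than the earlier compounds suggested: hydrogen in place of chloro gives a 32000-fold lower number from compound 2 to compound 4 (4.51 log units; beyond the scatter) and hydrogen in place of bromo gives a 16000-fold lower number from compound 1 to compound 4 (4.21 log units; beyond the scatter) on the same core. The swap between the two halogens gives a 2.0-fold higher number from compound 1 to compound 2 (0.29 log units; within the scatter) and stays within the scatter, so chloro and bromo read alike here while hydrogen stands far apart from both. Hydrogen at this spot does not bring a low number on every core shown, since compound 3 also carries it and gives 116000 nM while compound 4 gives 2 nM in this assay on its own core.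

On these data alone, whether a fluoro, a methoxy or an amine at this spot would read like the halogens or like hydrogen stays open. Nothing shown gives a reason for a step of this size.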